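A few compounds are considered here, and "the series" means these few. Any claim that something is new, unique, unknown or untested is made for them only; others in the source may bear on it.

Measured so far in a functional assay on A549 cells (Homo sapiens) for antiproliferative activity, read by MTT assay, with a stated time of 24 h; a lower number here means a stronger inhibitor, a higher number a weaker inhibitor:
- compound 1, `CNC(=O)c1ccccc1Oc1nc(Nc2ccc(Br)cc2)ncc1Br`: 23500 nM
- compound 2, `CNC(=O)c1ccccc1Oc1nc(Nc2ccc(C(F)(F)F)cc2)ncc1Br`: > 50000 nM; this is a limit of the assay, not a number
- compound 3, `CNC(=O)c1ccccc1Oc1nc(Nc2cccc(Br)c2)ncc1Br`: 10600 nM

Compound 1 stands highest of the two numbers given; its nearest neighbour is compound 3, reached by a 2.2-fold lower number from compound 1 to compound 3 (0.35 log units; beyond the scatter). Compound 2 contributes no number, only (the limit of > 50000 nM in this assay, at which 1 of the 3 values shown sits).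

Compound 4, `CNC(=O)c1ccccc1Oc1nc(Nc2ccccc2OC)ncc1Br`, differs from compound 1 in one place: 2-methoxyphenyl in place of 4-bromophenyl on a nitrogen on an aromatic ring.

Two measured steps start from compound 1 and touch the same ring. One is an at least 2.1-fold higher number from compound 1 to compound 2 (0.32 log units; beyond the scatter), which replaces the bromine with another group at the same place and weakens the compound to the limit. The other is a 2.2-fold lower number from compound 1 to compound 3 (0.35 log units; beyond the scatter), which keeps the bromine but moves it and strengthens the compound modestly. Neither step brings in a methoxy group, and the two point in opposite directions with modest sizes, so they set no clear direction for the present change. In this assay the step to compound 4 is therefore expected to be a 1.1-fold higher number from compound 1 to compound 4 (0.03 log units; within the scatter), not beyond the scatter, with a wide band to cover either outcome. The estimate for compound 4 in this assay is 25000 nM, expected between 8000 nM and 80000 nM.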

Compound 4, half-maximal inhibitory concentration: 40500 nM
Estimate against measurement, compound 4: 1.6-fold (0.21 log units) below, and the stated range covers the measured number.
By their numbers in this assay, from the lowest: compound 3; then compounds 1 and 4 (each within the scatter of the next). At a limit, above all of these: compound 2.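

In this assay, 2-methoxyphenyl in place of 4-bromophenyl on this nitrogen gives a 1.7-fold higher number from compound 1 to compound 4 (0.24 log units; within the scatter), so this first oxygen-bearing ring does not separate from compound 1, even though it brings a hydrogen-bond acceptor that 4-bromophenyl lacks. Set against the other bromo ring, the same kind of exchange gives a 3.8-fold higher number from compound 3 to compound 4 (0.58 log units; beyond the scatter), which leaves 3-bromophenyl as the only ring here whose number stands beyond the scatter from both compound 1 and compound 4. Compound 2 gives only a limit and not a number, so no step from it to compound 4 can be read: the limit of > 50000 nM in this assay, at which 1 of the 4 values shown sits.

Compound 4 differs from both bromo compounds in the group and in its place on the ring at once, so these two contributions remain unseparated in this set. Also open, on these data alone, is whether a ring carrying an amine or a carboxylic acid on this nitrogen would reach a number lower than that of compound 3, or whether the bromine on the core can be exchanged without loss.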